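Fluoro for Methoxy on a Scaffold Without Measurable Toxicity

A few compounds are considered here, and "the series" means these few. Any claim that something is new, unique, unknown or untested is made for them only; others in the source may bear on it.

In a functional assay on HeLa cells (Homo sapiens) for cytotoxicity, read by MTT assay, with a stated time of 24 h (on this read-out lower numbers stand for stronger inhibition and higher numbers for weaker inhibition), compound 2 `C=CC1=C(C(=O)Nc2ccccc2)C(c2ccc(OC)cc2)OC1` gives only a limit, > 100000 nM, which is not a measured number. Compound 1 `C=CC1=C(C(=O)NCc2ccccc2F)C(c2ccc(F)cc2)OC1` likewise returns only a limit, > 100000 nM. Both results sit at the limit of > 100000 nM in this assay, at which 2 of the 2 values shown sit, so nothing here separates the two. Compound 3 `C=CC1=C(C(=O)Nc2ccccc2)C(c2ccc(F)cc2)OC1` differs from compound 2 in one place: fluoro in place of methoxy on an aromatic carbon. Among the measured compounds shown here, no measured step between compounds stands behind this change, and no shift beyond the usual scatter is expected, so the step from compound 2 to compound 3 is estimated as a number no higher from compound 2 to compound 3 (the limit leaves the size open). Compound 3 is therefore expected to give 100000 nM, somewhere between 50000 nM and 300000 nM.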

Compound 3, half-maximal inhibitory concentration: > 100000 nM
Compound 3 gave a limit, no number; the forecaster's own chance of this, stated with the estimate: 85%; the middle value lies on the limit itself.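

In this assay compound 1, compound 2 and compound 3 each give only a limit, not a number, so no step between them can be read: the limit of > 100000 nM in this assay, at which 3 of the 3 values shown sit.

From the compounds shown here alone, whether fluoro or methoxy, or phenyl or 2-fluorobenzyl, changes cytotoxicity at all remains open.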